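The compounds below may be only part of what the source reports. "The series", "measured", "known", "first", "only" and "open" are said of these compounds alone.

Measured in a functional assay on SK-OV-3 cells (Homo sapiens) for cytotoxicity, read by MTT assay, with a stated time of 48 h; a higher number here means a weaker inhibitor, a lower number a stronger inhibitor:
compound 1, `Cc1cccc(C(=O)/C=C/c2ccc3c(c2)B(O)OC3)c1`: 2900 nM
compound 2, `O=C(/C=C/c1ccc2c(c1)B(O)OC2)c1cccc(O)c1`: 3800 nM
compound 3, `Nc1cccc(C(=O)/C=C/c2ccc3c(c2)B(O)OC3)c1`: 7400 nM

Compound 3 gives the highest number of the three. Its nearest neighbour is compound 2, and the step of a 1.9-fold higher number from compound 2 to compound 3 (0.29 log units; within the scatter) lies within the scatter; its furthest is compound 1, and the step of a 2.6-fold higher number from compound 1 to compound 3 (0.41 log units; beyond the scatter) lies beyond the scatter, though it is modest. The step of a 1.3-fold higher number from compound 1 to compound 2 (0.12 log units; within the scatter) is within the scatter.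

Compound 4, `COc1cccc(C(=O)/C=C/c2ccc3c(c2)B(O)OC3)c1`, is not yet measured. It differs from compound 3 in one place: methoxy in place of amino on an aromatic carbon. Both measured steps into compound 3 bear on this change, since each introduced the amino group onto the shared core in exchange for another group, and both gave higher numbers, one within and one beyond the scatter. Removing the amino group again is therefore expected to lower the number in this assay, but only by a modest step, as the reference steps were themselves small. Compound 4 is expected to give about 3500 nM in this assay, within a range of 1800 nM to 7000 nM. The expected step is a 2.1-fold lower number from compound 3 to compound 4 (0.33 log units; beyond the scatter).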

Compound 4, half-maximal inhibitory concentration: 2600 nM
Estimate against measurement, compound 4: 1.3-fold (0.13 log units) above, and the stated range covers the measured number.
By their numbers in this assay, from the lowest: compounds 4, 1, 2 and 3 (each within the scatter of the next, the first and the last beyond it).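

In this assay, the step of a 2.8-fold lower number from compound 3 to compound 4 (0.45 log units; beyond the scatter) lies beyond the scatter, so at this aromatic carbon, meta to a large group, amino now stands apart from methoxy as it does from methyl, while a 1.9-fold higher number from compound 2 to compound 3 (0.29 log units; within the scatter) still leaves it unresolved from hydroxy. The steps of a 1.5-fold lower number from compound 2 to compound 4 (0.16 log units; within the scatter) and a 1.1-fold lower number from compound 1 to compound 4 (0.05 log units; within the scatter) are both within the scatter, so methoxy cannot be separated from hydroxy or methyl here, and enlarging the entering group from methyl to methoxy shows no effect on the number. No available evidence bears on why amino differs from methoxy in this series.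

Going by these compounds, whether ethoxy, chlorine or a carboxylic acid at this place would stay level with methyl, hydroxy and methoxy remains open. On these data alone, whether the amino step holds at any other carbon of this ring also remains open.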